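Benzamide to Pyridinylmethyl Carbamate: Clearance Expectation

The source may report more compounds than this note shows. Statements on the series, on what has been measured and on what is new or still open speak of the compounds shown alone.

Measured so far, in an in vivo ADME assay on the whole organism (blood) for pharmacokinetics, with Rattus norvegicus as the target; on this read-out higher numbers stand for fast clearance and lower numbers for slow clearance:
- Compound 1, `Cc1cc(C(=O)NCc2ccccc2)nn1Cc1cc(Cl)ccc1OCc1ccccc1`, gives 75 mL/min/kg
- Compound 2, `Cc1cc(NC(=O)C2CCOCC2)nn1Cc1cc(Cl)ccc1OCc1ccccc1`, gives 55 mL/min/kg
- Compound 3, `Cc1cc(NC(=O)c2ccccc2)nn1Cc1cc(Cl)ccc1OCc1ccccc1`, gives 50 mL/min/kg

These three numbers sit close together. The step of a 1.5-fold lower number from compound 1 to compound 3 (0.18 log units; within the scatter) and the step of a 1.1-fold lower number from compound 2 to compound 3 (0.04 log units; within the scatter) both stay within the usual scatter, as does a 1.4-fold lower number from compound 1 to compound 2 (0.13 log units; within the scatter), so compound 3 cannot be set apart from its two neighbours on these measurements.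

Compound 4, `Cc1cc(NC(=O)OCc2ccccn2)nn1Cc1cc(Cl)ccc1OCc1ccccc1`, has not yet been measured. It differs from compound 3 by (pyridin-2-yl)methoxy in place of phenyl on a carbonyl carbon. The change that bears most directly on it is the swap of the carbonyl substituent seen from compound 2 to compound 3, which produced only a 1.1-fold lower number from compound 2 to compound 3 (0.04 log units; within the scatter). Among the measured compounds shown here, no measured pair covers a carbamate or a pyridine, so the shift here is not anchored. On that basis the expected step is a 1.1-fold higher number from compound 3 to compound 4 (0.04 log units; within the scatter), not beyond the scatter. For compound 4 the estimate in this assay is 55 mL/min/kg, with a range from 30 mL/min/kg to 110 mL/min/kg.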

Compound 4, clearance: 98 mL/min/kg
Beside the measured number, compound 4's estimate is 1.8-fold (0.25 log units) below it; the range from low to high includes it.
By their numbers in this assay, from the lowest: compounds 3, 2, 1 and 4 (each within the scatter of the next).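

Swapping phenyl for (pyridin-2-yl)methoxy on the carbonyl carbon gives a 2.0-fold higher number from compound 3 to compound 4 (0.29 log units; within the scatter) in this assay, so even this larger group, which adds a ring nitrogen and an oxygen and turns the benzamide into a carbamate, does not clearly separate the two compounds. The same holds against the other two compounds, with a 1.8-fold higher number from compound 2 to compound 4 (0.25 log units; within the scatter) and a 1.3-fold higher number from compound 1 to compound 4 (0.12 log units; within the scatter), so all the steps to compound 4 stay within the scatter and this position has not yet shown a clear effect on clearance. Nothing shown here explains where these numbers fall.

Still open, from the compounds shown here alone, is whether an amine or a carboxylic acid on this carbonyl carbon would produce a step beyond the scatter. A plain benzyloxy group in the same place could also help separate the part played by the carbamate from that of the pyridine ring.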